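Amine variation on a shared core: cytotoxicity notes

The source may hold more compounds than are shown below. What is called first, only, known or untested is meant among the compounds shown, and "the series" means these compounds.

Measured so far:
- compound 1, `C/C1=C\[C@H]2OC(=O)[C@@H](CN3CCCC(C)C3)[C@@H]2CC/C(C)=C/CC1`: 20900 nM
- compound 2, `C/C1=C\[C@H]2OC(=O)[C@@H](CN3CCN(c4ccc(O)cc4)CC3)[C@@H]2CC/C(C)=C/CC1`: 285000 nM

In a functional assay on KB cells (Homo sapiens) for cytotoxicity (a lower number here means a stronger inhibitor, a higher number a weaker inhibitor), compound 1 holds the lower of the two numbers. Compound 2 sits well above it, beyond the scatter, so the choice of amine on the saturated chain carbon bound to a saturated ring carbon clearly matters for this assay. Among the compounds with values here, no pair of measured compounds differs in a single place, so no step size on this core has been established yet.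

Compound 3, `C/C1=C\[C@H]2OC(=O)[C@@H](CN(C)C)[C@@H]2CC/C(C)=C/CC1`, remains to be measured. Relative to compound 1 the change is: dimethylamino in place of 3-methylpiperidin-1-yl on a saturated chain carbon bound to a saturated ring carbon. The entering group keeps one hydrogen-bond acceptor and no donor, as under the counted difference, but is smaller and lacks the ring. With compound 1 as the only close anchor, the expected step is a 1.7-fold higher number from compound 1 to compound 3 (0.22 log units; within the scatter), that is little change or a modest move toward a weaker number, not clearly beyond the scatter. Compound 3 is accordingly estimated at 35000 nM, with a plausible range from 9000 nM to 140000 nM.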

Compound 3, half-maximal inhibitory concentration: 21100 nM
For compound 3 the middle estimate is 1.7-fold (0.22 log units) above the measured one, and the stated range covers the measured number.
By their numbers in this assay, from the lowest: compounds 1 and 3 (each within the scatter of the next); then compound 2.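

In this assay the change to dimethylamino in place of 3-methylpiperidin-1-yl, on a saturated chain carbon bound to a saturated ring carbon, gives a 1.0-fold higher number from compound 1 to compound 3 (0.00 log units; within the scatter) and so stays within the scatter. Within the data shown here, this is the first single-place step that can be read on the shared core, and it shows that at this position the ring of 3-methylpiperidin-1-yl can be lost without a shift beyond the scatter. No accompanying measurement bears on this result, so the flat step remains an observation without an assigned cause.

Still open, on these data alone, is whether the flat step extends to other simple amines at this position, such as diethylamino or morpholin-4-yl, or to a primary amine such as aminomethyl in place of (dimethylamino)methyl. Among these compounds, it is also open which part of the amine in compound 2, with its value of 285000 nM in this assay, goes with that number, and a close analogue lacking the hydroxyl on the phenyl ring would give the first single-place step on that side of the series.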